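Methyl Placement on a Shared Aminopyrimidine Core

This account rests on a few compounds, and the source may have more. Where it says the series, first, only, none or still open, it means among the compounds named here.

Compounds measured so far:
- compound 1 `Cc1cc(C)cc(Nc2nccc(-c3cccnc3)n2)c1`: 800 nM
- compound 2 `Cc1cc(C)cc(Nc2ncc(C)c(-c3cccnc3)n2)c1`: > 24000 nM
- compound 3 `CN(C)c1cccc(Nc2nccc(-c3ccncc3)n2)c1`: 3700 nM

In a functional assay for inhibition, with Homo sapiens as the target (on this read-out lower numbers stand for stronger inhibition and higher numbers for weaker inhibition), compound 1 gives 800 nM. For compound 2 the value > 24000 nM is a limit of the assay, not a number; one of the three values shown sits at the limit of > 24000 nM in this assay, at which 1 of the 3 values shown sits. The change from compound 1 to compound 2 is methyl in place of hydrogen on an aromatic carbon, and it brings an at least 30-fold higher number from compound 1 to compound 2 (1.47 log units; beyond the scatter). Compound 3 gives 3700 nM in this assay, the highest of the two numbers available, with compound 1 the nearest. How the core of compound 3 differs from the core of compound 1 is not broken down here.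

Compound 4 `Cc1cc(-c2ccncc2)nc(Nc2cccc(N(C)C)c2)n1` has not yet been measured. Against compound 3 it shows (methyl in place of hydrogen on an aromatic carbon). Among the measured compounds shown here, this is the same kind of change as the one from compound 1 to compound 2, yet the surroundings differ: in compound 2 the methyl sits ortho to a pyridin-3-yl group, two atoms from the ring nitrogen and para to a group of 9 heavy atoms, whereas in compound 4 it sits next to the ring nitrogen, meta to a pyridin-4-yl group and opposite the ring nitrogen. For the measured compounds named here, the only measured step of this kind, an at least 30-fold higher number from compound 1 to compound 2 (1.47 log units; beyond the scatter), was large and toward weaker inhibition, and the place in compound 4 is not the same. A smaller step in the same direction is therefore expected for compound 4, the expected step being a 4.1-fold higher number from compound 3 to compound 4 (0.61 log units; beyond the scatter). Compound 4 is therefore expected to give about 15000 nM, most likely between 4000 nM and 50000 nM, with a real chance that only a limit is reported.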

Compound 4, half-maximal inhibitory concentration: > 24000 nM
Compound 4 was reported as a limit; the forecaster's own chance of this, stated with the estimate: 35%; middle value at least 1.6-fold (0.20 log units) away from the limit.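

On the core of compound 3, a methyl in place of hydrogen on an aromatic carbon gives an at least 6.4-fold higher number from compound 3 to compound 4 (0.81 log units; beyond the scatter) in this assay, so weaker inhibition follows this change on a second core too, even though the methyl does not stand in the same place as in compound 2. Compound 4 gives > 24000 nM, which is a limit of the assay and not a number, and it is not alone there: the limit of > 24000 nM in this assay, at which 2 of the 4 values shown sit. These two pairs do not show that the change costs the same on both cores, nor how large either loss really is, and they make no general rule for the series, since the true size of each step stays hidden: the same change on two cores in this assay, an at least 30-fold higher number (1.47 log units; beyond the scatter) from compound 1 to compound 2 and an at least 6.4-fold higher number (0.81 log units; beyond the scatter) from compound 3 to compound 4; the limit leaves it open whether they differ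

The compounds shown leave open whether the methyl itself matters or whether any group in these places would do the same, as a fluorine atom, a methoxy group or an amine could show. They also leave open what a methyl would do on each core in the place it holds on the other, which would separate the effect of the place from the effect of the core.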